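Bromo in place of chloro: a clearance estimate

The compounds below may be only part of what the source reports. "The series", "measured", "known", "first", "only" and "open" are said of these compounds alone.

Going by the values given here, in an in vitro ADME assay on microsomes from liver (Homo sapiens) for metabolic stability, in the presence of a further agent that is not named here (on this read-out lower numbers stand for slow clearance and higher numbers for fast clearance), compound 2 `COc1ccc(Cl)cc1Cn1c(C(=O)NCC(C)(C)CO)cc2cc(C#N)ccc21` gives 10 mL.min-1.g-1, the lower of the two numbers measured so far, while compound 1 `COc1ccc(OC(F)(F)F)cc1Cn1c(C(=O)NCC(C)(C)CO)cc2cc(C#N)ccc21` gives 31 mL.min-1.g-1. Compound 3 `COc1ccc(Br)cc1Cn1c(C(=O)NCC(C)(C)CO)cc2cc(C#N)ccc21` has bromo in place of chloro on an aromatic carbon, para to a methoxy group: bromo in place of chloro on an aromatic carbon. Among the compounds with values here, the only measured step at this place is a 3.1-fold lower number from compound 1 to compound 2 (0.49 log units; beyond the scatter), a modest step beyond the scatter. Within the data shown here, it involves trifluoromethoxy rather than bromo, so it shows only that the number in this assay can shift with a change here. Among the measured compounds shown here, no measured pair compares two halogens. A small change within the scatter is therefore expected, with a slight lean towards a higher number. The expected step is a 1.2-fold higher number from compound 2 to compound 3 (0.08 log units; within the scatter). Compound 3 is estimated at 12 mL.min-1.g-1, with an expected range of 7 mL.min-1.g-1 to 22 mL.min-1.g-1.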

Compound 3, intrinsic clearance in microsomes: 23 mL.min-1.g-1
Beside the measured number, compound 3's estimate is 1.9-fold (0.28 log units) below it; the whole stated range lies below it.
By their numbers in this assay, from the lowest: compound 2; then compounds 3 and 1 (each within the scatter of the next).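

In this assay, going by these compounds alone, the two halogens are not interchangeable at this place, on an aromatic carbon para to a methoxy group: the first measured comparison of two halogens here is a 2.3-fold higher number from compound 2 to compound 3 (0.36 log units; beyond the scatter) and so lies beyond the scatter. Bromo, however, stays close to trifluoromethoxy (a 1.3-fold lower number from compound 1 to compound 3 (0.13 log units; within the scatter)), which leaves chloro as the only one of the three groups set apart from the other two. Nothing at hand explains why chloro stands apart from bromo.

The compounds shown leave open where fluoro, a methyl group, a nitrile or an amine would fall at this place. They also leave open whether chloro would keep its lower number if the nitrile or the amide side chain on the shared core were replaced, for instance by a carboxylic acid or a longer chain.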